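Swapping a Bromophenyl Arm for Thiophene

The compounds below may be only part of what the source reports. "The series", "measured", "known", "first", "only" and "open" are said of these compounds alone.

Compound 1 `Cc1nc(NC(=O)c2ccccc2)sc1C(=O)/C=C/c1ccc(Br)cc1` gives 52.3% in an assay for inhibition of Polyunsaturated fatty acid 5-lipoxygenase (Homo sapiens), read by spectrophotometry, tested at 10 uM, in the presence of a further agent that is not named here; on this read-out higher numbers stand for more inhibition at the one concentration tested (going by the name of the read-out) and lower numbers for less inhibition.
Compound 2 `COc1cc(/C=C/C(=O)c2sc(NC(=O)c3ccccc3)nc2C)cc(OC)c1OC` gives 100%.
Compound 3 `COc1ccc(C(=O)Nc2nc(C)c(C(=O)/C=C/c3ccc(C)cc3)s2)cc1` gives 100%.

The three compounds share one core and differ only in the groups at either end. Compound 1 stands lowest of the three numbers; compound 2 and compound 3 both lie well above it, each by a gap beyond the usual scatter. For the measured compounds named here, no two measured compounds differ in a single place, so no measured step is available. Going by these compounds, compound 4 `Cc1nc(NC(=O)c2ccccc2)sc1C(=O)/C=C/c1cccs1` is untested and differs from compound 1 in one place: thiophen-2-yl in place of 4-bromophenyl on a double-bonded chain carbon bound to a double-bonded chain carbon. Going by the values given here, with no measured step for such a change, the expected step is small, within the scatter: a number 2.7 percentage points higher from compound 1 to compound 4 (within the scatter). Compound 4 is therefore estimated at 55%, within the range 25% to 90%.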

Compound 4, a percentage reported as inhibition, at one concentration (the size of the read-out at that concentration, not a potency): 71.9%
Compound 4: the middle estimate sits 16.9 percentage points below what was measured; the range from low to high includes it.
By their numbers in this assay, from the lowest: compound 1; then compound 4; then compounds 2 and 3 (each within the scatter of the next).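

In this assay, thiophen-2-yl in place of 4-bromophenyl gives a number 19.6 percentage points higher from compound 1 to compound 4 (beyond the scatter) with the rest of the molecule unchanged. For the compounds shown here, this is the first single-place comparison in the set: it shows that the group at this end of the chain alone can shift the read-out, and that inhibition here does not depend on the 4-bromophenyl ring. Nothing shown explains the rise. Going by these compounds, whether it follows from losing the bromine or from changing the ring stays open. So does the effect of a plain phenyl or a furan-2-yl group at this place.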